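Acetamido for cyclopentyloxy: expected cytotoxicity of compound 4

A few compounds are considered here, and "the series" means these few. Any claim that something is new, unique, unknown or untested is made for them only; others in the source may bear on it.

Compound 1, `O=C(Nc1nc(-c2ccccc2)cs1)c1ccc([N+](=O)[O-])o1`, gives 41700 nM in an ADME assay on Vero cells (Chlorocebus sabaeus) for cytotoxicity, read by MTT assay, with a stated time of 72 h; a higher number here means a weaker inhibitor, a lower number a stronger inhibitor.
Compound 2, `O=C(Nc1nc(-c2cccc(C(F)(F)F)c2)cs1)c1ccc([N+](=O)[O-])o1`, gives 23900 nM.
Compound 3, `O=C(Nc1nc(-c2cccc(OC3CCCC3)c2)cs1)c1ccc([N+](=O)[O-])o1`, gives 81100 nM.

These three compounds share one core and differ only in a single group on an aromatic carbon. In this assay compound 3 sits at the upper end of the three numbers: its gap to compound 1 is within the scatter a 1.9-fold higher number from compound 1 to compound 3 (0.29 log units; within the scatter), while its gap to compound 2 lies beyond it a 3.4-fold higher number from compound 2 to compound 3 (0.53 log units; beyond the scatter).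

Compound 4, `CC(=O)Nc1cccc(-c2csc(NC(=O)c3ccc([N+](=O)[O-])o3)n2)c1`, carries acetamido in place of cyclopentyloxy on an aromatic carbon. The two measured steps that touch the same position both put cyclopentyloxy in place of something else, giving a within-scatter rise from compound 1 and a modest rise from compound 2. Among the measured compounds shown here, no measured step involves acetamido, so its effect in this assay cannot be read from the data. For the measured compounds named here, replacing the one group that coincided with the upper end of the numbers leaves an expectation of a number drifting back toward compound 1, but not clearly beyond the scatter.

Compound 4 is therefore expected to give 50000 nM, with a range from 20000 nM to 120000 nM. The expected step is a 1.6-fold lower number from compound 3 to compound 4 (0.21 log units; within the scatter).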

Compound 4, half-maximal inhibitory concentration: 57600 nM
The estimate for compound 4 lay 1.2-fold (0.06 log units) below the measured number; measured number inside the range.
By their numbers in this assay, from the lowest: compounds 2, 1, 4 and 3 (each within the scatter of the next, the first and the last beyond it).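

The step from cyclopentyloxy to acetamido swaps a carbon ring for an open group that brings a hydrogen-bond donor, yet in this assay it stays within the scatter (a 1.4-fold lower number from compound 3 to compound 4 (0.15 log units; within the scatter)), and acetamido in place of hydrogen does too (a 1.4-fold higher number from compound 1 to compound 4 (0.14 log units; within the scatter)). This position, meta to a large group, therefore accepts a second, quite different substituent without a clear separation from the unsubstituted compound 1. Trifluoromethyl now differs beyond the scatter from both larger groups (a 2.4-fold higher number from compound 2 to compound 4 (0.38 log units; beyond the scatter) and a 3.4-fold higher number from compound 2 to compound 3 (0.53 log units; beyond the scatter)), although compound 1 goes against any simple split because its step to compound 2 stays within the scatter (a 1.7-fold lower number from compound 1 to compound 2 (0.24 log units; within the scatter)), and no measurement shown here accounts for these differences.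

As far as these compounds go, it remains open whether a free amine or a carboxylic acid at this position would stay level with compound 1 or fall closer to compound 2. Nor can these compounds tell whether a longer chain, such as butoxy, would keep the number in the same range as compound 3 and compound 4.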